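The source may report more compounds than this note shows. Statements on the series, on what has been measured and on what is new or still open speak of the compounds shown alone.

Of the compounds shown here, three that share one core have been tested in a functional assay on HepG2 cells (Homo sapiens) for antiproliferative activity, read by sulforhodamine B assay, with a stated time of 3 days; on this read-out higher numbers stand for an effect only at larger amounts of compound and lower numbers for an effect already at smaller amounts. Compound 1 `CCCOC1=C(CCC)C(=O)/C(=C(O)/C=C/c2ccccc2)C(=O)C1(CCC)CCC` gives 8.3 uM. Compound 2 `CCCC1=C(OCC(C)C)C(CCC)(CCC)C(=O)/C(=C(O)\C=C\c2ccccc2)C1=O` gives 13.4 uM. Compound 3 `COC1=C(CC=C(C)C)C(=O)/C(=C(O)/C=C/c2ccccc2)C(=O)C1(CC=C(C)C)CC=C(C)C` gives 11.2 uM. Of these three numbers compound 2 is nearest to compound 3 and furthest from compound 1, yet every gap between them lies within the usual scatter of repeated measurements, so none of the three stands apart from the others.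

Among the compounds with values here, the only step between measured compounds that differ in a single place runs from compound 1 to compound 2, where a methyl replaces a hydrogen on a saturated chain carbon bound to two saturated chain carbons; in this assay it reads a 1.6-fold higher number from compound 1 to compound 2 (0.21 log units; within the scatter).

Compound 4 `CCCC1=C(OCC)C(CCC)(CCC)C(=O)/C(=C(O)\C=C\c2ccccc2)C1=O` is not yet measured. It differs from compound 2 in one place: methyl in place of isopropyl on a saturated chain carbon bound to an oxygen on an unsaturated carbon. Cut one bond further out, this reads isobutoxy to ethoxy, a shortening of the same chain that the step from compound 1 to compound 2 lengthened. That step is the only one that bears on the present change, and its size stayed inside the scatter. A step of no more than the scatter is therefore expected here too, in either direction, and compound 4 is expected to give 10 uM in this assay, with a range from 5 uM to 20 uM. The step that this estimate means is a 1.3-fold lower number from compound 2 to compound 4 (0.13 log units; within the scatter).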

Compound 4, concentration for half-maximal effect: 11.2 uM
Beside the measured number, compound 4's estimate is 1.1-fold (0.05 log units) below it; the measured number falls inside the stated range.
By their numbers in this assay, from the lowest: compounds 1, 3, 4 and 2 (each within the scatter of the next).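

In this assay, within the data shown here, the earlier compounds showed only a chain growing on the ether oxygen, whereas isobutoxy giving way to ethoxy now tests a chain cut back at this place and gives a 1.2-fold lower number from compound 2 to compound 4 (0.08 log units; within the scatter). The ethoxy chain of compound 4 can also be set against the propoxy chain of compound 1, which gives a 1.3-fold higher number from compound 1 to compound 4 (0.13 log units; within the scatter), so all three chains on this oxygen, from the methyl-for-isopropyl change to the loss of a single methyl, remain inseparable by this read-out, and neither shortening nor branching has yet produced a step that stands out from repeat-measurement noise. Nothing measured here accounts for how close these numbers lie.

Still open, going by these compounds, is whether a much longer chain such as octyl, a benzyl group, or a chain ending in an amine or a carboxylic acid at this place would move the number beyond the scatter. Also open is whether a free hydroxyl in place of the ether would do so, as every compound shown keeps a simple ether chain on this oxygen.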